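Carbamoyl for Carboxymethyl: Expected Binding of Compound 3

The source may hold more compounds than are shown below. What is called first, only, known or untested is meant among the compounds shown, and "the series" means these compounds.

Measured so far:
Compound 1, `O=C(O)CCCCCOc1cc(-c2ccccc2)cc(-c2ccccc2)n1`: 3 nM
Compound 2, `O=C(O)CCCCCCOc1cc(-c2ccccc2)cc(-c2ccccc2)n1`: 25 nM

In an assay on cell membranes from spleen (Cavia porcellus) for binding affinity to leukotriene B4 receptor 1 (Homo sapiens) (a higher number here means a weaker inhibitor, a lower number a stronger inhibitor), compound 2 stands at the higher of the two numbers, set apart from compound 1 by a step that runs an 8.3-fold higher number from compound 1 to compound 2 (0.92 log units; beyond the scatter). Compound 3, `NC(=O)CCCCCOc1cc(-c2ccccc2)cc(-c2ccccc2)n1`, has not yet been measured in this assay. It differs from compound 2 by carbamoyl in place of carboxymethyl on a saturated chain carbon, five bonds along the chain from an oxygen on an aromatic ring. The change has two parts: the chain is cut back to the length found in compound 1, and the acid end is exchanged for an amide. Only the first part has a measured counterpart, the step of an 8.3-fold higher number from compound 1 to compound 2 (0.92 log units; beyond the scatter) run in reverse, which on its own would point to a lower number. Among the measured compounds shown here, no measured pair shows what the exchange of acid for amide does, so that part remains open. The expected step is a 1.3-fold lower number from compound 2 to compound 3 (0.10 log units; within the scatter), with wide uncertainty. Compound 3 is therefore estimated at 20 nM, within a range of 3 nM to 150 nM.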

Compound 3, half-maximal inhibitory concentration: 160 nM
Estimate against measurement, compound 3: 8.0-fold (0.90 log units) below; the whole stated range lies below it.
By their numbers in this assay, from the lowest: compound 1; then compound 2; then compound 3.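

Compound 1 and compound 3 differ only in amino in place of hydroxy on a carbonyl carbon, and in this assay this exchange alone gives a 53-fold higher number from compound 1 to compound 3 (1.73 log units; beyond the scatter), the largest step among these compounds. Among the compounds shown here, this is the first measured view of what replacing the acid with an amide does, and it outweighs the shorter chain: the combined change gives a 6.4-fold higher number from compound 2 to compound 3 (0.81 log units; beyond the scatter), so the amide in compound 3 does not regain the stronger binding of compound 1. The data shown offer no measured explanation for this loss.

Still open, going by these compounds, is whether a methyl ester or a tetrazole in place of the amide would give a number closer to that of compound 1 or compound 3. Also open, on these data alone, is how a shorter chain ending in a carboxylic acid would compare with compound 1.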